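Substituent variation on the saturated ring carbon

A few compounds are considered here, and "the series" means these few. Any claim that something is new, unique, unknown or untested is made for them only; others in the source may bear on it.

Measured compounds:
compound 1 `Cc1nn(-c2ncnc3nc[nH]c23)c2c1C(OC1CCCC1)CC(=O)N2` gives 62 nM
compound 2 `Cc1nn(-c2ncnc3nc[nH]c23)c2c1C(OCc1ccc(Cl)cc1Cl)CC(=O)N2` gives 243 nM
compound 3 `Cc1nn(-c2ncnc3nc[nH]c23)c2c1C(NC(=O)Cc1cccs1)CC(=O)N2` gives 244 nM

In a functional assay on HEK293 cells for agonist activity at G-protein coupled receptor 39 (Homo sapiens), read by scintillation proximity assay and inositol phosphate accumulation, with a stated time of 75 min (on this read-out higher numbers stand for an effect only at larger amounts of compound and lower numbers for an effect already at smaller amounts), compound 3 stands at the highest of the three numbers. Its number and that of compound 2 lie within the scatter of each other, as a 1.0-fold higher number from compound 2 to compound 3 (0.00 log units; within the scatter) shows; against compound 1 the gap is a 3.9-fold higher number from compound 1 to compound 3 (0.59 log units; beyond the scatter), beyond the scatter.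

Compound 4 `Cc1nn(-c2ncnc3nc[nH]c23)c2c1C(C(=O)N(C)c1ccccc1)CC(=O)N2` differs from compound 3 by methyl(phenyl)carbamoyl in place of (((thiophen-2-yl)methyl)carbonyl)amino on a saturated ring carbon.

Going by the values given here, two measured steps concern this ring carbon: a 3.9-fold higher number from compound 1 to compound 3 (0.59 log units; beyond the scatter) and a 1.0-fold higher number from compound 2 to compound 3 (0.00 log units; within the scatter). They show that exchanging the group at this position has so far moved the number by a modest amount at most, and that two quite different groups, in compound 2 and compound 3, gave numbers within the scatter of each other. Among the compounds with values here, no measured step exchanges a group of this kind for a methyl(phenyl)carbamoyl, so the expectation rests on the spread seen here only. For compound 4 a step of a 1.2-fold higher number from compound 3 to compound 4 (0.09 log units; within the scatter) is expected, most likely within or barely beyond the scatter, with no firm direction.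

Compound 4 is therefore estimated at 300 nM, with a range from 90 nM to 1000 nM.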

Compound 4, half-maximal effective concentration: 5220 nM
Compound 4: middle estimate off by 17-fold (1.24 log units), on the low side; measured number above the stated range.
By their numbers in this assay, from the lowest: compound 1; then compounds 2 and 3 (each within the scatter of the next); then compound 4.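

In this assay, this ring carbon proves far less forgiving than compound 1, compound 2 and compound 3 alone suggested: a 21-fold higher number from compound 3 to compound 4 (1.33 log units; beyond the scatter), a 21-fold higher number from compound 2 to compound 4 (1.33 log units; beyond the scatter) and an 84-fold higher number from compound 1 to compound 4 (1.93 log units; beyond the scatter) are all large, whereas the earlier exchanges were modest at most. Among the four groups, only methyl(phenyl)carbamoyl is joined to the ring carbon through its carbonyl carbon, the others being joined through oxygen or an amino nitrogen, but a single compound cannot separate this change of linkage from the presence of the phenyl ring or the methyl group. No available measurement accounts for the large steps.

Still open, from the compounds shown here alone, is whether a phenylcarbamoyl without the methyl, or a carbamoyl carrying cyclopentyl in place of phenyl, would return to the range of compound 2 and compound 3, which would show which part of the new group goes with the step. Also open, going by these compounds, is how a free amine, a carboxylic acid or a longer alkyl ether at this ring carbon would read in this assay.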